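Benzyl-substituted aminopyrazolopyrimidine series: chloro for trifluoromethyl

The compounds below may be only part of what the source reports. "The series", "measured", "known", "first", "only" and "open" are said of these compounds alone.

Measured so far:
Compound 1, `CC(C)Cc1nc(N)c2nn(-c3ccccc3)cc2n1`: 49%
Compound 2, `Cc1ccc(Cc2nc(N)c3nn(-c4ccccc4)cc3n2)cc1`: 38%
Compound 3, `Nc1nc(Cc2cccc(C(F)(F)F)c2)nc2cn(-c3ccccc3)nc12`: 1%

In an assay on CHO cells for displacement of a labelled ligand from adenosine receptor A1 (Homo sapiens), read by scintillation counting, tested at 1 uM (on this read-out higher numbers stand for more inhibition at the one concentration tested (going by the name of the read-out) and lower numbers for less inhibition), compound 3 gives the lowest of the three numbers; compound 2 lies well above it, and compound 1 further still, both gaps beyond the scatter. Compound 4, `Nc1nc(Cc2cccc(Cl)c2)nc2cn(-c3ccccc3)nc12`, differs from compound 3 by chloro in place of trifluoromethyl on an aromatic carbon. Going by the values given here, the only measured step, a number 11 percentage points lower from compound 1 to compound 2 (beyond the scatter), concerns the saturated chain carbon and not the aromatic substituent, so no step bears directly on this change. Among the compounds with values here, compounds 2 and 3 show only that a substituted benzyl group without trifluoromethyl gave a higher number. On that basis a small upward step a number 11 percentage points higher from compound 3 to compound 4 (beyond the scatter) is expected, though it may fall within the scatter. Compound 4 is therefore estimated at 12%, with a range of 0% to 35%.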

Compound 4, a percentage reported as inhibition, at one concentration (the size of the read-out at that concentration, not a potency): 32%
Beside the measured number, compound 4's estimate is 20 percentage points below it; the measured number falls inside the stated range.
By their numbers in this assay, from the lowest: compound 3; then compounds 4 and 2 (each within the scatter of the next); then compound 1.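

In this assay, the aromatic carbon meta to a large group is sensitive to this change: chloro in place of trifluoromethyl gives (a number 31 percentage points higher from compound 3 to compound 4 (beyond the scatter)), so the low number of compound 3 goes with trifluoromethyl at this place and not with the aryl-bearing chain as such. The 3-chlorophenyl group does not separate from 4-methylphenyl (a number 6 percentage points lower from compound 2 to compound 4 (within the scatter)) but stays apart from isopropyl (a number 17 percentage points lower from compound 1 to compound 4 (beyond the scatter)). No measurement on hand accounts for the size of the chloro step.

Open, as far as these compounds go, is whether fluoro, methoxy or an amine at this place would track chloro or trifluoromethyl.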